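From compound 3 to compound 4 in a cytotoxicity test

The compounds below may be only part of what the source reports. "The series", "measured", "known", "first", "only" and "open" are said of these compounds alone.

Of the compounds shown here, three that share one core have been tested in a toxicity assay on MDCK cells (Canis lupus familiaris) for cytotoxicity, read by crystal violet staining, with a stated time of 48 h; on this read-out higher numbers stand for lower toxicity in this test and lower numbers for higher toxicity in this test. Compound 1 `Cc1ccc2cc(CN(Cc3ccc(C(C)C)cc3)Cc3ccccc3F)c(=O)[nH]c2c1` gives > 33000 nM in this assay, a value that is a limit of the assay rather than a number. Compound 2 `CCc1ccc2[nH]c(=O)c(CN(Cc3ccc(F)cc3)Cc3ccc(C(C)(C)C)cc3)cc2c1` gives > 33000 nM in this assay, again a limit. Compound 3 `COc1ccc(CN(Cc2ccc(C(C)(C)C)cc2)Cc2cc3cc(C)ccc3[nH]c2=O)cc1` gives > 10000 nM in this assay, also a limit. Compound 3 therefore stands where no exact number is known: it sits at the limit of > 10000 nM in this assay, at which 1 of the 3 values shown sits, while the other two sit at the limit of > 33000 nM in this assay, at which 2 of the 3 values shown sit. Nothing in these three values allows any ordering among the compounds.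

Compound 4 `Cc1ccc2[nH]c(=O)c(CN(Cc3ccc(C(C)(C)C)cc3)[C@@H](C)c3ccc(F)cc3)cc2c1` has not yet been measured in this assay. It differs from compound 3 in one place: 1-(4-fluorophenyl)ethyl in place of 4-methoxybenzyl on an amine nitrogen. Going by the values given here, no two measured compounds here differ in a single place, so no measured step is available to guide the expectation. With every value shown being a limit, the expected step from compound 3 to compound 4 is a step that the limit leaves unreadable from compound 3 to compound 4, that is, none beyond the scatter. Compound 4 is accordingly estimated at 40000 nM in this assay, within a range from 15000 nM to 100000 nM, and it is expected that the result will most likely again be reported only as a limit.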

Compound 4, half-maximal cytotoxic concentration: > 5000 nM
Compound 4 gave a limit, no number (the forecaster's own chance of this, stated with the estimate: 85%); the middle value lies beyond the limit too.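

In this assay compound 3 and compound 4 are both known only as limits of the assay, so the step between them, 1-(4-fluorophenyl)ethyl in place of 4-methoxybenzyl on an amine nitrogen, cannot be read. The compounds shown leave open at what concentration any of them would harm these cells, and whether this exchange changes that concentration at all.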